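This account rests on a few compounds, and the source may have more. Where it says the series, first, only, none or still open, it means among the compounds named here.

Compound 1 `C=CCOc1nc(N)nc2c1ncn2/C=C1/CC1(CO)CO` gives in an ADME assay on MOLT-3 cells (Homo sapiens) for cytotoxicity, with a stated time of 7 days (on this read-out higher numbers stand for lower toxicity in this test and lower numbers for higher toxicity in this test), a value that is only a limit, > 20000 nM. Compound 2 `CCCCCCCCOc1nc(N)nc2c1ncn2/C=C1/CC1(CO)CO` likewise gives only a limit, > 20000 nM. Compound 3 `Nc1nc2c(ncn2/C=C2/CC2(CO)CO)c(=O)[nH]1` also gives only a limit, > 20000 nM.

Compound 2 thus stands where every measured compound stands, at the limit of this assay (the limit of > 20000 nM in this assay, at which 3 of the 3 values shown sit). For the measured compounds named here, the single measured step, a step that the two limits leave unreadable from compound 1 to compound 2, cannot be read because both of its ends are limits (the limit of > 20000 nM in this assay, at which 3 of the 3 values shown sit). Compound 4 `CCCCCCCCSc1nc(N)nc2c1ncn2/C=C1/CC1(CO)CO` differs from compound 2 by octylsulfanyl in place of octyloxy on an aromatic carbon. Going by the values given here, no measured step matches this change, and with all values at the limit no step beyond the scatter can be anticipated in this assay. Compound 4 is therefore expected to give about 30000 nM, within 12000 nM to 100000 nM. The expected step is a step that the limit leaves unreadable from compound 2 to compound 4.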

Compound 4, half-maximal cytotoxic concentration: > 20000 nM
Compound 4: no number, only a limit (the forecaster's own chance of this, stated with the estimate: 80%); the middle value is on the limit's open side.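

Compound 4 also gives only a limit, so neither its step from compound 1 nor its step from compound 2 can be read: the limit of > 20000 nM in this assay, at which 4 of the 4 values shown sit. The compounds shown leave open whether octylsulfanyl, octyloxy and allyloxy differ at all in this assay.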